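The source may hold more compounds than are shown below. What is called first, only, known or untested is meant among the compounds shown, and "the series" means these compounds.

In a functional assay on A549 cells (Homo sapiens) for antiproliferative activity, read by MTT assay, with a stated time of 48 h (a higher number here means a weaker inhibitor, a lower number a stronger inhibitor), the three measured compounds stand as follows.
Compound 1 `Cc1ccccc1-n1nncc1CN1C(=O)C2(C(C#N)=C(N)Oc3c(N)cc4nc5ccccc5nc4c32)c2ccccc21` gives 31700 nM.
Compound 2 `N#CC1=C(N)Oc2c(N)cc3nc4ccccc4nc3c2C12C(=O)N(Cc1cnnn1-c1ccc(F)cc1)c1ccccc12` reaches only the assay limit of > 50000 nM.
Compound 3 `N#CC1=C(N)Oc2c(N)cc3nc4ccccc4nc3c2C12C(=O)N(Cc1cnnn1-c1ccc(Cl)cc1[N+](=O)[O-])c1ccccc12` likewise reaches only the assay limit of > 50000 nM.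

Compound 3 therefore sits at the limit, where (the limit of > 50000 nM in this assay, at which 2 of the 3 values shown sit). Compound 4 `COc1cc(-n2nncc2CN2C(=O)C3(C(C#N)=C(N)Oc4c(N)cc5nc6ccccc6nc5c43)c3ccccc32)c(OC)cc1Cl` differs from it in a single place: 4-chloro-2,5-dimethoxyphenyl in place of 4-chloro-2-nitrophenyl on an aromatic nitrogen. Among the compounds with values here, two measured steps touch this position. Replacing 2-methylphenyl produced an at least 1.5-fold higher number from compound 1 to compound 3 (0.19 log units; that floor lies within the scatter), and the exchange between the two limit values produced a step that the two limits leave unreadable from compound 2 to compound 3. Every change of the group on this aromatic nitrogen has so far left the number at or near the limit, so compound 4 is expected to remain there as well, with a number no higher from compound 3 to compound 4 (the limit leaves the size open). Compound 4 is estimated at 50000 nM, within 20000 nM to 120000 nM.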

Compound 4, half-maximal inhibitory concentration: > 50000 nM
Compound 4: only a limit was reported; the forecaster's own chance of this, stated with the estimate: 65%; the middle value sits exactly at the limit.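

With 4-chloro-2,5-dimethoxyphenyl on the aromatic nitrogen, a ring without the nitro group, compound 4 also gives only a limit, so three different substituted phenyl groups at this position now share it: the limit of > 50000 nM in this assay, at which 3 of the 4 values shown sit. Against 2-methylphenyl the change gives an at least 1.5-fold higher number from compound 1 to compound 4 (0.19 log units; that floor lies within the scatter) and compound 1 remains the only one with a readable number. The steps to compound 4 from compound 2 and from compound 3 cannot be read. On these data alone, whether an amine or a carboxylic acid on this phenyl ring, or a longer chain in its place, would bring the number clear of the limit stays open.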